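The compounds below may be only part of what the source reports. "The series", "measured", "known", "first", "only" and "open" are said of these compounds alone.

In a functional assay on J82 cells (Homo sapiens) for cytotoxicity, read by colorimetric assay and MTT assay (on this read-out lower numbers stand for stronger inhibition and higher numbers for weaker inhibition), compound 1 `COc1cccc2cc(-c3ccccc3)c(O)nc12` gives 10000 nM and stands level with the other two measured compounds. Compound 2 `COc1ccc2cc(-c3ccccc3)c(O)nc2c1` gives 10000 nM and compound 3 `COc1cc(OC)c2cc(-c3ccccc3)c(O)nc2c1` gives 10000 nM on the same read-out, so the three cannot be told apart. Compound 4 `COc1ccc(-c2cc3cccc(OC)c3nc2O)cc1` keeps the core of compound 1 and differs from it by a single swap, methoxy in place of hydrogen on an aromatic carbon in one place: on an aromatic carbon of a six-membered aromatic ring of carbon only, para to a large group. For the measured compounds named here, the only measured step of the same kind, methoxy in place of hydrogen on an aromatic carbon, is no change at the digits printed from compound 2 to compound 3 (within the scatter) and it lies within the scatter, although it falls elsewhere on the molecule. One step is thin evidence, but on that step alone no change beyond the scatter is expected in this assay in either direction. The expected step is no change at the digits printed from compound 1 to compound 4 (within the scatter) on this reasoning. The estimated value for compound 4 is 10000 nM with an expected range from 4000 nM to 20000 nM around it.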

Compound 4, half-maximal inhibitory concentration: 10000 nM
Beside the measured number, compound 4's estimate shows no gap at the digits printed; measured number inside the range.
By their numbers in this assay, from the lowest: compounds 1, 2, 3 and 4 (each within the scatter of the next).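

At this position, para to a large group on a six-membered aromatic ring of carbon only, adding methoxy in place of hydrogen gives no change at the digits printed from compound 1 to compound 4 (within the scatter) in this assay. For the compounds shown here, the earlier compounds showed this swap only elsewhere on the molecule, so this is the first reading of the change at this position. The swap now reads alike in two places on two cores: the same change on two cores in this assay, no change at the digits printed (within the scatter) from compound 2 to compound 3 and no change at the digits printed (within the scatter) from compound 1 to compound 4, 1.0-fold (0.00 log units) apart, within the scatter of two such steps

Going by these compounds, whether a different group at this position, such as an amine, a carboxylic acid or a longer chain like butoxy, would shift the value remains open. All four compounds stand level, so the set holds no step beyond the scatter, and it cannot yet show which parts of the molecule matter in this assay.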